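Methyl on the Fused Ring Nitrogen: Estimating Compound 3

The source may hold more compounds than are shown below. What is called first, only, known or untested is meant among the compounds shown, and "the series" means these compounds.

Compound 1 `O=C(Nc1ccc(Oc2ccnc3[nH]ccc23)cc1)c1nn(-c2ccc(Br)cc2)ccc1=O`: 6240 nM
Compound 2 `O=C(Nc1ccc(Oc2ccnc3[nH]ccc23)cc1)c1nn(-c2ccc(Cl)c(C(F)(F)F)c2)ccc1=O`: 2190 nM

Of the two compounds measured in a functional assay on A549 cells (Homo sapiens) for cytotoxicity, read by MTT assay, with a stated time of 72 h (on this read-out lower numbers stand for stronger inhibition and higher numbers for weaker inhibition), compound 1 stands at the highest number. Going by the values given here, the only measured step is a 2.8-fold lower number from compound 1 to compound 2 (0.45 log units; beyond the scatter), in which 4-chloro-3-(trifluoromethyl)phenyl replaces 4-bromophenyl on an aromatic nitrogen. Compound 3 `Cn1ccc2c(Oc3ccc(NC(=O)c4nn(-c5ccc(Br)cc5)ccc4=O)cc3)ccnc21` has not yet been measured. It differs from compound 1 by methyl in place of hydrogen on an aromatic nitrogen, a methyl in place of hydrogen on an aromatic nitrogen of a five-membered aromatic ring with 1 nitrogen, part of a fused or bridged system of two rings. Among the compounds with values here, no measured step concerns this place; the single step available changes the aryl group elsewhere and offers no guide here. Without a comparable step, the change is expected to give a 1.4-fold higher number from compound 1 to compound 3 (0.16 log units; within the scatter) in this assay, a weakening that may not exceed the scatter. Compound 3 is therefore estimated at 9000 nM, with a range from 3000 nM to 30000 nM.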

Compound 3, half-maximal inhibitory concentration: 59400 nM
The estimate for compound 3 lay 6.6-fold (0.82 log units) below the measured number; measured number outside the range, above it.
By their numbers in this assay, from the lowest: compound 2; then compound 1; then compound 3.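

In this assay, the hydrogen on this aromatic nitrogen proves far from neutral: replacing it with methyl, a change of one carbon atom, gives a 9.5-fold higher number from compound 1 to compound 3 (0.98 log units; beyond the scatter) in a single step. Going by these compounds alone, the earlier step, a 2.8-fold lower number from compound 1 to compound 2 (0.45 log units; beyond the scatter) at the aryl group, said nothing about this part of the molecule, so this is the first sign that the position is sensitive to change. The result shows only that this methyl is poorly tolerated in these cells, and no measurement shown here explains why. From the compounds shown here alone, it remains open whether a larger group, such as ethyl or a longer chain, would weaken the number further on this nitrogen. Going by these compounds, it also remains open whether the same methyl would have a similar effect on compound 2, with its different aryl group.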